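A few compounds are considered here, and "the series" means these few. Any claim that something is new, unique, unknown or untested is made for them only; others in the source may bear on it.

Two members of the series have been measured so far. Compound 1 `COc1ccc([C@@H]2C/C(=N\O)c3c(O)cc(OCc4cn(Cc5ccccc5C)nn4)cc3O2)cc1O` gives 18000 nM in a functional assay on RAW264.7 cells (Mus musculus) for inhibition, read by Griess assay, with stated times of 2 h and 24 h; on this read-out lower numbers stand for stronger inhibition and higher numbers for weaker inhibition. Compound 2 `COc1ccc([C@@H]2C/C(=N\O)c3c(O)cc(OCc4cn(-c5ccccc5)nn4)cc3O2)cc1O` gives 6130 nM in this assay. For the measured compounds named here, the single step between them is a 2.9-fold lower number from compound 1 to compound 2 (0.47 log units; beyond the scatter), and on the two numbers in hand compound 2 stands at the lower one, with compound 1 the higher by a margin beyond the scatter.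

The next compound, compound 3 `COc1ccc([C@@H]2C/C(=N\O)c3c(O)cc(OCc4cn(Cc5ccccc5Cl)nn4)cc3O2)cc1O`, differs from compound 2 in one place: 2-chlorobenzyl in place of phenyl on an aromatic nitrogen. Going by the values given here, this change bears directly on the one measured step, because it is close to the reverse of a 2.9-fold lower number from compound 1 to compound 2 (0.47 log units; beyond the scatter): there a phenyl on the aromatic nitrogen replaced a 2-methylbenzyl and the number fell; here a 2-chlorobenzyl replaces the phenyl. Since compound 1, carrying the 2-methylbenzyl, gives 18000 nM, the expectation for compound 3 is a number of about that size, a step back up from compound 2 of roughly the magnitude seen before. The expected step is a 2.3-fold higher number from compound 2 to compound 3 (0.36 log units; beyond the scatter). Compound 3 is therefore estimated at 14000 nM, with a range from 6000 nM to 32000 nM.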

Compound 3, half-maximal inhibitory concentration: 13400 nM
For compound 3 the middle estimate is 1.0-fold (0.02 log units) above the measured one, within the range that was stated.
By their numbers in this assay, from the lowest: compound 2; then compounds 3 and 1 (each within the scatter of the next).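

In this assay, with the group on the aromatic nitrogen of the five-membered ring with 3 nitrogen, 2-chlorobenzyl now joins 2-methylbenzyl on the higher side of phenyl: a 2.2-fold higher number from compound 2 to compound 3 (0.34 log units; beyond the scatter). The earlier gap is therefore not particular to 2-methylbenzyl, and among these three compounds phenyl gives the lowest number, though three compounds are a narrow base for any wider pattern. Exchanging the substituent on the benzyl group gives a 1.3-fold lower number from compound 1 to compound 3 (0.13 log units; within the scatter), so chloro and methyl are not separated on this read-out, and no other measurement here bears on the reason for either step.

Phenyl and the two benzyl groups differ both in the added carbon link and in the substituent on the aromatic ring, so the compounds shown do not separate these two changes. An unsubstituted benzyl and a 2-chlorophenyl would bear directly on that question, while a group carrying an amine or a carboxylic acid at this position remains an open case for the series.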